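Same swap on a second core: a cytotoxicity estimate

The source may hold more compounds than are shown below. What is called first, only, known or untested is meant among the compounds shown, and "the series" means these compounds.

Compound 1 `CS/C(=N\C(=O)c1ccno1)NC(=O)c1ccno1`: in a functional assay on HT-29 cells (Homo sapiens) for cytotoxicity, read by MTT assay, with a stated time of 72 h (on this read-out lower numbers stand for higher toxicity in this test and higher numbers for lower toxicity in this test), compound 1 shows only the assay limit > 100000 nM.
Compound 2 `O=C(/N=C(/NC(=O)c1ccno1)[Se]Cc1ccccc1)c1ccno1`: in this assay compound 2 shows only the assay limit > 100000 nM.
Compound 3 `O=C(/N=C(/NC(=O)c1cccs1)[Se]Cc1ccccc1)c1cccs1`: in this assay compound 3 shows only the assay limit > 100000 nM.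

Compound 2 and compound 1 share one core and differ in a single place: a group of 2 heavy atoms (1 carbon, 1 sulfur; no ring) in place of a group of 8 heavy atoms (7 carbon, 1 selenium; one six-membered aromatic ring of carbon only), on a carbon with a double bond to nitrogen. The step that the two limits leave unreadable from compound 2 to compound 1 cannot be sized because both values sit at the limit of > 100000 nM in this assay, at which 3 of the 3 values shown sit. Compound 3 carries a second core; how its core differs from that of compound 2 is not broken down here. Compound 4 `CS/C(=N\C(=O)c1cccs1)NC(=O)c1cccs1` is not yet measured and differs from compound 3 by a group of 2 heavy atoms (1 carbon, 1 sulfur; no ring) in place of a group of 8 heavy atoms (7 carbon, 1 selenium; one six-membered aromatic ring of carbon only), on a carbon with a double bond to nitrogen, the same change as between compound 2 and compound 1. Since compound 3 gives only a limit and the same change gave the unreadable step that the two limits leave unreadable from compound 2 to compound 1, compound 4 is expected to stay at the limit as well, with an expected step that the limit leaves unreadable from compound 3 to compound 4 of roughly nil. Compound 4 is therefore estimated at 150000 nM (between 50000 nM and 500000 nM) in this assay, most likely reported only as a limit.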

Compound 4, concentration lethal to 50% of the cells: > 100000 nM
Compound 4: no number, only a limit; the forecaster's own chance of this, stated with the estimate: 85%; the middle value does not contradict the limit.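

Compound 3 and compound 4 both give only an assay limit, so no step can be read between them: the limit of > 100000 nM in this assay, at which 4 of the 4 values shown sit. As far as these compounds go, whether methylsulfanyl and the group it replaces differ at all in toxicity in this assay stays open.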